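Methyl to hydrogen on the furan-2-yl group: compound 3

The compounds below may be only part of what the source reports. "The series", "measured", "known", "first", "only" and "open" are said of these compounds alone.

Among the compounds with values here, compound 1 `Cc1ccc(-c2nc3ccccc3n2CC(=O)N/N=C/c2ccccc2Cl)o1` is one of two compounds so far with a number in a functional assay on HepG2 cells (Homo sapiens) for cytotoxicity, read by sulforhodamine B assay, with a stated time of 48 h; a lower number here means a stronger inhibitor, a higher number a weaker inhibitor. In this assay compound 1 gives 22600 nM, the lower of the two values. Within the data shown here, compound 2 `SC1=NNCC(n2c(-c3ccco3)nc3ccccc32)=N1`, built on the shared core with a different pendant, gives 62100 nM in this assay, a value that lies beyond the scatter from that of compound 1; no single-point step connects the two, so the pair shows only that compound 1 holds the lower number.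

Compound 3 `O=C(Cn1c(-c2ccco2)nc2ccccc21)N/N=C/c1ccccc1Cl` has not yet been measured in this assay. It differs from compound 1 in one place: hydrogen in place of methyl on an aromatic carbon, or read one bond further out, 5-methylfuran-2-yl to furan-2-yl. Among the measured compounds shown here, no measured pair shows a step of this kind, so nothing here calibrates it. A change of one carbon, with no ring and no donor or acceptor, is expected to move the number only a little, with no direction beyond the scatter. Compound 3 is therefore estimated at 30000 nM, between 12000 nM and 75000 nM. The expected step of a 1.3-fold higher number from compound 1 to compound 3 (0.12 log units; within the scatter) in this assay stays within the scatter.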

Compound 3, half-maximal inhibitory concentration: 26000 nM
Beside the measured number, compound 3's estimate is 1.2-fold (0.06 log units) above it, and the stated range covers the measured number.
By their numbers in this assay, from the lowest: compounds 1 and 3 (each within the scatter of the next); then compound 2.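

In this assay the series now has its first step between compounds that differ in one place (a 1.2-fold higher number from compound 1 to compound 3 (0.06 log units; within the scatter)), and it lies within the scatter. On an aromatic carbon of the five-membered aromatic ring with 1 oxygen, next to the ring oxygen, 5-methylfuran-2-yl and furan-2-yl therefore cannot be told apart in this read-out, and the number of compound 1 does not depend measurably on this methyl. Nothing measured on these compounds accounts for this outcome.

As far as these compounds go, this single step covers only the exchange of methyl for hydrogen, so it remains open whether a group such as ethyl, aminomethyl or a carboxylic acid at the same place would separate from compound 1 and compound 3 by more than the scatter. Compound 3 is also the only one-place neighbour of compound 1 shown so far, which leaves open whether the same exchange would read the same way with a different pendant on the shared core.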